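A swap to 2,6-dichlorophenyl: expected cytotoxicity

A few compounds are considered here, and "the series" means these few. Any claim that something is new, unique, unknown or untested is made for them only; others in the source may bear on it.

- Compound 1 `Cc1ccc(N(C(=O)c2cc(F)ccc2F)C(=S)OCCN2C(=O)c3ccccc3C2=O)cc1`: 62000 nM
- Compound 2 `Cc1ccc(N(C(=O)c2ccc(Cl)cc2Cl)C(=S)OCCN2C(=O)c3ccccc3C2=O)cc1`: 49000 nM

Both numbers come from an ADME assay on MT4 cells (Homo sapiens) for cytotoxicity, read by MTT assay; on this read-out higher numbers stand for lower toxicity in this test and lower numbers for higher toxicity in this test. Within the data shown here, only two compounds have been measured so far, and compound 2 cannot be told apart from compound 1: the step is a 1.3-fold lower number from compound 1 to compound 2 (0.10 log units; within the scatter).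

The next molecule, compound 3 `Cc1ccc(N(C(=O)c2c(Cl)cccc2Cl)C(=S)OCCN2C(=O)c3ccccc3C2=O)cc1`, keeps the shared core and has 2,6-dichlorophenyl in place of 2,4-dichlorophenyl on a carbonyl carbon. Among the measured compounds shown here, the only measured step that bears on this is the earlier exchange of groups on that same carbonyl carbon, a 1.3-fold lower number from compound 1 to compound 2 (0.10 log units; within the scatter). For the measured compounds named here, no measured compound carries 2,6-dichlorophenyl, so this is indirect evidence from a single step. The estimated step is a 1.0-fold higher number from compound 2 to compound 3 (0.01 log units; within the scatter), so no change beyond the scatter is expected in this assay. Compound 3 is expected at 50000 nM, with an estimated range of 22000 nM to 110000 nM.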

Compound 3, half-maximal cytotoxic concentration: 22000 nM
Estimate against measurement, compound 3: 2.3-fold (0.36 log units) above; the measured number falls inside the stated range.
By their numbers in this assay, from the lowest: compound 3; then compounds 2 and 1 (each within the scatter of the next).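

In this assay the group on the carbonyl carbon now gives a step beyond the scatter, a 2.2-fold lower number from compound 2 to compound 3 (0.35 log units; beyond the scatter), even though 2,4-dichlorophenyl and 2,6-dichlorophenyl have the same atoms, joined differently. Against the 2,5-difluorophenyl group the step is also beyond the scatter, a 2.8-fold lower number from compound 1 to compound 3 (0.45 log units; beyond the scatter), and both steps are modest but point towards higher toxicity in this test for the 2,6-dichlorophenyl group. So at this position, how the two chlorines are arranged on the ring can shift the number, though nothing shown here explains the shift.

The compounds shown leave open whether a plain phenyl or a 2,6-difluorophenyl group on the same carbonyl carbon would give a similar number. They also leave open whether this step would hold if another part of the shared core were changed.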